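A few compounds are considered here, and "the series" means these few. Any claim that something is new, unique, unknown or untested is made for them only; others in the source may bear on it.

Compound 1 `O=[N+]([O-])c1cccc(/N=N/N2CCCCC2)c1` carries a nitro group on a six-membered aromatic ring of carbon only. In an ADME assay on BHK-21 cells (Mesocricetus auratus) for cytotoxicity, read by MTT assay, with a stated time of 96 h (a lower number here means that less compound is tolerated, a higher number that more compound is tolerated), compound 1 gives only a limit, > 100000 nM, rather than a number. Among the three values shown, compound 1 sits at the limit of > 100000 nM in this assay, at which 1 of the 3 values shown sits. Compound 2 `Cc1c(/N=N/c2ccccc2)ccc(NC[C@@H]2CCCN3CCCC[C@H]23)c1C` gives 47000 nM in this assay, and compound 3 `CN(C)CCCN(/N=N/c1ccccc1)c1cccc(C(F)(F)F)c1` gives 49000 nM, two values within the scatter of each other. Compound 4 `c1ccc(/N=N/N2CCCCC2)cc1` has not yet been measured in this assay; it differs from compound 1 by hydrogen in place of nitro on an aromatic carbon. Among the measured compounds shown here, no step between measured compounds covers this change, so in this assay no step beyond the scatter is expected in either direction. Compound 4 is estimated at 100000 nM, with a range from 40000 nM to 250000 nM. The expected step is a number no higher from compound 1 to compound 4 (the limit leaves the size open), and a limit rather than a number is thought likely.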

Compound 4, half-maximal cytotoxic concentration: > 100000 nM
Compound 4 gave a limit, no number; the forecaster's own chance of this, stated with the estimate: 60%; the middle value lies on the limit itself.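

No step can be read from compound 1 to compound 4 in this assay, because both give only a limit: the limit of > 100000 nM in this assay, at which 2 of the 4 values shown sit.

The compounds shown leave open whether hydrogen in place of nitro on an aromatic carbon changes the tolerated concentration in this assay at all.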